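Notes on compound 3, a ring stereoisomer of compound 1

The source may hold more compounds than are shown below. What is called first, only, known or untested is meant among the compounds shown, and "the series" means these compounds.

Measured so far in a functional assay on SF-539 cells (Homo sapiens) for inhibition; a higher number here means a weaker inhibitor of growth, a lower number a stronger inhibitor of growth:
compound 1 `C=C1CCCC(C)(C)C1CC[C@]1(C)CC[C@@H]([C@@H](C)C(=O)O)OO1` gives > 10000 nM, a limit of the assay and not a number
compound 2 `C=C1CCC[C@H]2[C@](C)(CC[C@]3(C)CC[C@@H]([C@@H](C)C(=O)O)OO3)[C@@H](C)CC[C@]12C` gives 1070 nM

Compound 1 stands only at a limit of this assay. Its entry is the limit of > 10000 nM in this assay, at which 1 of the 2 values shown sits, so nothing beyond that bound is known of it. Among the compounds with values here, compound 2 is the only member with a measured number; it carries the same substituent chain as compound 1 on a different core, so no step between the two is counted, and the two values show only that compound 2 returns a number where compound 1 does not.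

Compound 3 `C=C1CCCC(C)(C)C1CC[C@@]1(C)CC[C@H]([C@@H](C)C(=O)O)OO1` differs from compound 1 only in configuration: the two compounds have the same atoms and bonds; at least one stereo element is drawn with a configuration in one of them and without one in the other: 2 of 4 stereo elements differ; a stereocentre at a saturated ring carbon is drawn R in compound 1 and S in compound 3; a stereocentre at a saturated ring carbon is drawn S in compound 1 and R in compound 3. Within the data shown here, no measured pair compares two stereoisomers, so no size of step can be read from the numbers. With compound 1 at the limit, the step from compound 1 to compound 3 is expected to be a number no higher from compound 1 to compound 3 (the limit leaves the size open), taken against a bound rather than a number, and is expected to lie within the scatter. Compound 3 is expected to give about 10000 nM, within 2500 nM to 40000 nM, with a fair chance that only a limit is reported again.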

Compound 3, concentration for 50% growth inhibition: 3280 nM
Beside the measured number, compound 3's estimate is 3.0-fold (0.48 log units) above it; the measured number falls inside the stated range.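

In this assay, a change confined to the configuration of two stereocentres at saturated ring carbons, with nothing entering or leaving, gives an at least 3.0-fold lower number from compound 1 to compound 3 (0.48 log units; beyond the scatter). The earlier compounds shown here could not show this, since compound 2 differs from compound 1 in its core and no step between those two is counted; here the atoms and bonds stay the same, and configuration at these ring carbons alone separates a compound at the limit from one with a measured number. One end of this step is a limit and not a number, so its full size stays open: the limit of > 10000 nM in this assay, at which 1 of the 3 values shown sits.

From the compounds shown here alone, how far the drawn configurations can be taken as the whole of the difference remains uncertain: the fact that one of compounds 1 and 3 is drawn with a defined configuration and the other without, at the place where they differ Also open are whether the same change of configuration would matter on the core of compound 2, and whether the step would persist if the carboxylic acid were replaced by a methyl ester or a primary amide.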